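Piperidinyl for diisopropylamino on two stilbenyl-quinazoline cores

The source may hold more compounds than are shown below. What is called first, only, known or untested is meant among the compounds shown, and "the series" means these compounds.

Measured so far in a functional assay on L02 cells (Homo sapiens) for cytotoxicity, read by MTT assay, with stated times of 48 h and 4 h; a higher number here means a weaker inhibitor, a lower number a stronger inhibitor:
compound 1 `COc1ccc(/C=C/c2nc(NCCN(C(C)C)C(C)C)c3ccccc3n2)cc1OC`, reported only as a limit, > 100000 nM
compound 2 `COc1ccc(/C=C/c2nc(NCCN3CCCCC3)c3ccccc3n2)cc1OC`, 19800 nM
compound 3 `CC(C)N(CCNc1nc(/C=C/c2ccc([N+](=O)[O-])cc2)nc2ccc(Cl)cc12)C(C)C`, reported only as a limit, > 100000 nM

Compound 1 sits at a limit of this assay and gives no number. For the measured compounds named here, compound 2 gives a number, and the step of an at least 5.0-fold lower number from compound 1 to compound 2 (0.70 log units; beyond the scatter) is the only measured step. The change behind it is piperidin-1-yl in place of diisopropylamino on a saturated chain carbon, two bonds along the chain from a nitrogen on an aromatic ring. Compound 3 also sits at a limit of this assay and gives no number; that two of the three values stand at the same limit is noted in the limit of > 100000 nM in this assay, at which 2 of the 3 values shown sit. How the core of compound 3 differs from the core of compound 1 is not broken down here.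

Compound 4 `O=[N+]([O-])c1ccc(/C=C/c2nc(NCCN3CCCCC3)c3cc(Cl)ccc3n2)cc1` has not been measured in this assay. It stands to compound 3 as compound 2 stands to compound 1: the change is piperidin-1-yl in place of diisopropylamino on a saturated chain carbon, two bonds along the chain from a nitrogen on an aromatic ring, the same change as before, at the same place in the same words. For compound 4 the step of an at least 3.3-fold lower number from compound 3 to compound 4 (0.52 log units; beyond the scatter) is expected to run in the same direction as the earlier one, on the ground that the same change gave an at least 5.0-fold lower number from compound 1 to compound 2 (0.70 log units; beyond the scatter). Since compound 3 is only known as a limit, the size of the step can only be set loosely. Compound 4 is expected to give about 30000 nM in this assay, with a range from 8000 nM to 100000 nM.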

Compound 4, half-maximal inhibitory concentration: > 100000 nM
Compound 4 was reported as a limit; the forecaster's own chance of this, stated with the estimate: 35%; at least 3.3-fold (0.52 log units) between middle value and limit.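

Compound 3 and compound 4 are both reported only as limits in this assay, so no new step can be read from this pair: the limit of > 100000 nM in this assay, at which 3 of the 4 values shown sit.

The compounds shown leave open whether piperidin-1-yl in place of diisopropylamino lowers the number on the core of compound 3 at all, as it does on the core of compound 1.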